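A Thioether Swap on a Shared Core

The source may hold more compounds than are shown below. What is called first, only, known or untested is meant among the compounds shown, and "the series" means these compounds.

Compound 1 `Cc1cc(Nc2ccn(Cc3cccc4ccccc34)n2)n2nc(SCc3ccc(Br)cc3)nc2n1`: 5660 nM
Compound 2 `Cc1cc(Nc2cc(-c3ccccc3)[nH]n2)n2nc(SCC3CCCCC3)nc2n1`: a limit, > 50000 nM
Compound 3 `C=CCSc1nc2nc(C)cc(Nc3cc(-c4ccccc4)[nH]n3)n2n1`: a limit, > 50000 nM

In a functional assay on PC-9 cells (Homo sapiens) for inhibition, read by MTT assay, with a stated time of 72 h (a lower number here means a stronger inhibitor, a higher number a weaker inhibitor), compound 1 gives 5660 nM. Compound 2 reaches only a limit of the assay, > 50000 nM. Compound 3 likewise gives only a limit, > 50000 nM. Among the measured compounds shown here, the one measured step, a step that the two limits leave unreadable from compound 2 to compound 3, cannot be read because both values sit at the limit of > 50000 nM in this assay, at which 2 of the 3 values shown sit. Compound 2 therefore stands at the weak end of what this set shows, with no number of its own.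

Compound 4 `Cc1cc(Nc2cc(-c3ccccc3)[nH]n2)n2nc(SCc3ccc(C(F)(F)F)cc3)nc2n1` differs from compound 2 in one place: 4-(trifluoromethyl)phenyl in place of cyclohexyl on a saturated chain carbon bound to a sulfur. For the measured compounds named here, no measured step bears directly on this change; the only step in the set is unreadable. Compound 1 also carries a benzyl group on the sulfur, though its other part differs, and it shows that such a thioether can give a readable number. On that slender ground a move toward a readable value is expected for compound 4, at 20000 nM with a range from 5000 nM to 50000 nM. The expected step is an at least 2.5-fold lower number from compound 2 to compound 4 (0.39 log units; beyond the scatter), with a real chance that only a limit is reported.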

Compound 4, half-maximal inhibitory concentration: 4240 nM
Beside the measured number, compound 4's estimate is 4.7-fold (0.67 log units) above it; the measured number lies below the stated range.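

Putting 4-(trifluoromethyl)phenyl in place of cyclohexyl on a saturated chain carbon bound to a sulfur brings an at least 11-fold lower number from compound 2 to compound 4 (1.07 log units; beyond the scatter), which shows that in this assay a change at this one place can lift a compound off the limit. The same group in place of vinyl brings an at least 11-fold lower number from compound 3 to compound 4 (1.07 log units; beyond the scatter), so both of these steps, unlike the earlier one, can be read as a minimum size. Compound 2 and compound 3 each stand at a limit, not a number, and the step between them cannot be read: the limit of > 50000 nM in this assay, at which 2 of the 4 values shown sit.

Left open is whether plain phenyl in that place would give the same gain, which would separate the aromatic ring from the trifluoromethyl on it. Also open, going by these compounds, is how a ring carrying an amine or a carboxylic acid, or a longer chain between the sulfur and the ring, would fare.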